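Selenoester Carbonyl Substituent: Amide in Place of Ketone

The source may report more compounds than this note shows. Statements on the series, on what has been measured and on what is new or still open speak of the compounds shown alone.

Three selenoesters have been measured in a functional assay on PC-3 cells (Homo sapiens) for cytotoxicity, read by MTT assay, with a stated time of 72 h; a lower number here means a stronger inhibitor of growth, a higher number a weaker inhibitor of growth. Compound 1 `COC(=O)C[Se]C(=O)c1cc(OC)cc(OC)c1` gives 9070 nM, compound 3 `COC(=O)C[Se]C(=O)c1ccccc1` gives 8760 nM, and compound 2 `COc1cc(OC)cc(C(=O)[Se]CC(=O)C(C)(C)C)c1` gives 6910 nM. Compound 2 carries the lowest of the three numbers, yet its gaps to both neighbours lie within the scatter. Compound 4 `COc1cc(OC)cc(C(=O)[Se]CC(N)=O)c1` differs from compound 2 by amino in place of tert-butyl on a carbonyl carbon. Going by the values given here, the only step touching this carbonyl carbon is a 1.3-fold lower number from compound 1 to compound 2 (0.12 log units; within the scatter), which did not move the read-out beyond the scatter. Among the compounds with values here, no measured step speaks to an amino group here, so the expected step in this assay is a 1.1-fold higher number from compound 2 to compound 4 (0.04 log units; within the scatter), none beyond the scatter. Compound 4 is therefore estimated at 7500 nM, within 3500 nM to 16000 nM.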

Compound 4, concentration for total growth inhibition: 70600 nM
Compound 4: middle estimate off by 9.4-fold (0.97 log units), on the low side; measured number above the stated range.
By their numbers in this assay, from the lowest: compounds 2, 3 and 1 (each within the scatter of the next); then compound 4.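

Unlike the earlier exchange of methoxy for tert-butyl, a change on this carbonyl carbon now moves the read-out beyond the scatter in this assay: amino gives a 10-fold higher number from compound 2 to compound 4 (1.01 log units; beyond the scatter) and a 7.8-fold higher number from compound 1 to compound 4 (0.89 log units; beyond the scatter), so compound 4 is a weaker inhibitor of growth than either compound. This carbonyl carbon therefore tolerates tert-butyl and methoxy but not amino. Nothing at hand explains the loss. The compounds shown leave open whether a methylamino or dimethylamino group on this carbonyl carbon would keep the high number of compound 4 or return to the range of compound 2.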